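Acyl amides on the shared core: paw edema inhibition

The source may report more compounds than this note shows. Statements on the series, on what has been measured and on what is new or still open speak of the compounds shown alone.

Compound 3 `COC(=O)C(=O)NC1=C(C#N)C2C(N3CCCC3)CCCCN2C(=O)N1c1ccccc1` carries a ((methoxycarbonyl)carbonyl)amino group on the shared core. In a functional assay on the whole organism (strain albino) for inhibition, with Rattus norvegicus as the target, read by paw edema, with stated times of 1 h and 3 h, at a dose of 20 mmol/kg by the intraperitoneal route (on this read-out higher numbers stand for a stronger effect at the one dose given and lower numbers for a weaker effect), compound 3 gives 88.3%, the second highest of the three numbers. Compound 2 `N#CC1=C(/N=C/c2ccc([N+](=O)[O-])cc2)N(c2ccccc2)C(=O)N2CCCCC(N3CCCC3)C12` gives 91.7%, and the gap a number 3.4 percentage points lower from compound 2 to compound 3 (within the scatter) is within the scatter. Compound 1 `N#CC1=C(NCN2CCCCC2)N(c2ccccc2)C(=O)N2CCCCC(N3CCCC3)C12` gives 42.1%, far lower, so that a number 46.2 percentage points higher from compound 1 to compound 3 (beyond the scatter) and a number 49.6 percentage points higher from compound 1 to compound 2 (beyond the scatter) are both large.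

Compound 4 `N#CC1=C(NC(=O)c2ccccc2O)N(c2ccccc2)C(=O)N2CCCCC(N3CCCC3)C12` differs from compound 3 by 2-hydroxyphenyl in place of methoxycarbonyl on a carbonyl carbon. The step that bears most directly on this amine position is the large rise a number 46.2 percentage points higher from compound 1 to compound 3 (beyond the scatter); the small gap a number 3.4 percentage points lower from compound 2 to compound 3 (within the scatter) shows that an aromatic ring and an oxalyl group on the double-bonded ring carbon read alike. Compound 4 is therefore expected to stay near compound 3, with a step of a number 5.3 percentage points lower from compound 3 to compound 4 (within the scatter) of no size beyond the scatter. The estimate for compound 4 is 83%, expected within 62% to 95%.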

Compound 4, a percentage reported as inhibition, in the whole organism at one dose (the size of the read-out at that dose, not a potency): 65.4%
Beside the measured number, compound 4's estimate is 17.6 percentage points above it; measured number inside the range.
By their numbers in this assay, from the lowest: compound 1; then compound 4; then compounds 3 and 2 (each within the scatter of the next).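

On a carbonyl carbon, 2-hydroxyphenyl in place of methoxycarbonyl is not a neutral exchange in this assay (a number 22.9 percentage points lower from compound 3 to compound 4 (beyond the scatter)), so the amide-type series responds to the group on this carbonyl. An aromatic ring in the group on the double-bonded ring carbon does not ensure the highest numbers (a number 26.3 percentage points lower from compound 2 to compound 4 (beyond the scatter)), yet (2-hydroxyphenyl)carbonyl still reads above (piperidin-1-yl)methyl (a number 23.3 percentage points higher from compound 1 to compound 4 (beyond the scatter)). No evidence on the origin of these steps is available.

From the compounds shown here alone, whether the drop belongs to the ring or to its hydroxy group stays open. A plain phenyl, a carboxylic acid or an amine on the same carbonyl carbon would separate these readings.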